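Compound 3 to compound 4: a new group on nitrogen

A few compounds are considered here, and "the series" means these few. Any claim that something is new, unique, unknown or untested is made for them only; others in the source may bear on it.

In a physicochemical assay for solubility (on this read-out lower numbers stand for lower solubility and higher numbers for higher solubility), compound 1 `O=C(c1ccc(C(F)(F)F)cc1)N1CCC(NS(=O)(=O)c2cc(S(=O)(=O)c3ccccc3)ccc2C(F)(F)F)CC1` gives 6300 nM while compound 2 `CN(C)c1ccc(C(=O)N2CCC(NS(=O)(=O)c3cc(S(=O)(=O)c4ccccc4)ccc3C(F)(F)F)CC2)cc1` gives 50000 nM and compound 3 `O=C(c1ccc(Cl)nc1)N1CCC(NS(=O)(=O)c2cc(S(=O)(=O)c3ccccc3)ccc2C(F)(F)F)CC1` gives 25000 nM on the same shared core. Compound 3 thus stands within the scatter of compound 2 and clearly higher than compound 1.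

The next molecule, compound 4 `O=C(O)c1ccc(S(=O)(=O)N2CCC(NS(=O)(=O)c3cc(S(=O)(=O)c4ccccc4)ccc3C(F)(F)F)CC2)cc1`, swaps the whole group on the amine nitrogen in a ring, and (4-carboxyphenyl)sulfonyl in place of (6-chloropyridin-3-yl)carbonyl on an amine nitrogen in a ring sets out what is exchanged. Among the measured compounds shown here, none of the three measured compounds has a sulfonyl group on this nitrogen, so no measured step matches this swap directly.

The closest guides are changes within the group on the same nitrogen. Two are modest, a 7.9-fold higher number from compound 1 to compound 2 (0.90 log units; beyond the scatter) and a 4.0-fold higher number from compound 1 to compound 3 (0.60 log units; beyond the scatter) and both start from the lowest compound. The third, a 2.0-fold lower number from compound 2 to compound 3 (0.30 log units; within the scatter) shows that two quite different groups here can give values within the scatter of each other. Starting from compound 3, a large step therefore seems unlikely, and the new carboxyphenyl group leaves real uncertainty.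

The expected move is a 1.6-fold higher number from compound 3 to compound 4 (0.20 log units; within the scatter) and so no clear step beyond the scatter is anticipated. For compound 4 the estimate is 40000 nM (expected range 12000 nM to 130000 nM).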

Compound 4, solubility: 12500 nM
Estimate against measurement, compound 4: 3.2-fold (0.51 log units) above; measured number inside the range.
By their numbers in this assay, from the lowest: compounds 1, 4, 3 and 2 (each within the scatter of the next, the first and the last beyond it).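

Compound 4 is the only compound shown with a sulfonyl link on the amine nitrogen in a ring, and its (4-carboxyphenyl)sulfonyl group brings a carboxylic acid to this position. In this assay the exchange stays within the scatter in two comparisons, a 2.0-fold lower number from compound 3 to compound 4 (0.30 log units; within the scatter) and a 2.0-fold higher number from compound 1 to compound 4 (0.30 log units; within the scatter), while only the comparison with the dimethylamino compound goes beyond it, with a 4.0-fold lower number from compound 2 to compound 4 (0.60 log units; beyond the scatter). This position therefore accepts a sulfonyl-linked group carrying an acid with a read-out that stays in the span set by the three carbonyl-linked groups, and nothing measured here speaks to the reason for these numbers.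

The sulfonyl link and the carboxylic acid enter together in a single exchange, so the compounds shown cannot say how much of the step belongs to either one. A plain phenylsulfonyl group without the acid, or a 4-carboxybenzoyl group on the same nitrogen, would separate the two, and a primary amide or methyl ester in place of the acid remains an open comparison as well.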